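The compounds below may be only part of what the source reports. "The series", "measured", "known", "first", "only" and "open" are said of these compounds alone.

Measured so far in an assay on SH-EP1 cells for agonist activity at Neuronal acetylcholine receptor; alpha4/beta2 (Homo sapiens), read by FLIPR and calcium flux; on this read-out higher numbers stand for an effect only at larger amounts of compound and lower numbers for an effect already at smaller amounts:
compound 1 `O=C(C1CCC1)N1CC2CC(C1)N2` gives 2900 nM
compound 2 `O=C(C1CCCC1)N1CC2CC(C1)N2` gives 11000 nM
compound 3 `O=C(C1CC=CC1)N1CC2CC(C1)N2` gives 6600 nM

Among these three numbers compound 1 stands lowest in this assay; compound 3 comes nearest, with a number beyond the scatter above it, and compound 2 lies furthest, also beyond the scatter. The three differ only in the carbon ring that sits on the carbonyl, and the cyclobutyl of compound 1 is the one that acts at the smallest amount.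

Compound 4 `C[C@@H]1C[C@H]1C(=O)N1CC2CC(C1)N2` has not been measured. It differs from compound 1 in one place: 2-methylcyclopropyl in place of cyclobutyl on a carbonyl carbon. The two compounds hold the same atoms, joined differently; a four-membered ring gives way to a three-membered ring carrying a methyl, with two defined stereocentres. Within the data shown here, no step between measured compounds covers such a change, so the direction rests on little. Since the cyclobutyl of compound 1 already gives the lowest number of the three, the expectation is that compound 4 stays close to it, with the step from compound 1 to compound 4 estimated as a 1.0-fold higher number from compound 1 to compound 4 (0.01 log units; within the scatter), not clearly beyond the scatter in either direction. Compound 4 is therefore expected to give about 3000 nM, within a range from 1000 nM to 9000 nM.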

Compound 4, half-maximal effective concentration: 190 nM
Compound 4: middle estimate off by 16-fold (1.20 log units), on the high side; the whole stated range lies above it.
By their numbers in this assay, from the lowest: compound 4; then compound 1; then compounds 3 and 2 (each within the scatter of the next).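

In this assay the change from cyclobutyl to 2-methylcyclopropyl on the carbonyl carbon is a large one, a 15-fold lower number from compound 1 to compound 4 (1.18 log units; beyond the scatter), even though the two groups hold the same atoms. Among these compounds, the earlier compounds varied only a single carbon ring on the carbonyl, and their printed values left open how far this position could move; compound 4 shows that rejoining the same carbons into a three-membered ring carrying a methyl, with two defined stereocentres, places it below all three. Nothing measured here accounts for this step.

The compounds shown leave open whether the methyl, the three-membered ring or the particular stereocentres carry the step, since neither plain cyclopropyl nor any other stereoisomer of 2-methylcyclopropyl is among them. On these data alone, how an ethyl or an amine in place of that methyl would read in this assay also remains open.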